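The compounds below may be only part of what the source reports. "The series", "measured", "known", "first", "only" and "open" are said of these compounds alone.

Three compounds here share one core. Compound 1 `COc1ccc(Br)cc1CCc1c(F)cccc1C(=O)/N=C(\N)NCCN1CCCC1` carries a pyrrolidin-1-yl at the end of its chain; in a functional assay for antagonist activity at Melanocortin receptor 4 (Homo sapiens), read by cAMP accumulation (on this read-out higher numbers stand for weaker inhibition and lower numbers for stronger inhibition), compound 1 gives 4500 nM. Compound 2 `CCCC/N=C(/N)NC(=O)c1cccc(F)c1CCc1cc(Br)ccc1OC` carries a plain butyl chain, and in this assay compound 2 gives "not determined" (no result reported), so no number exists for it. Compound 3 `COc1ccc(Br)cc1CCc1c(F)cccc1C(=O)/N=C(\N)NCCCCN(C)Cc1ccccc1` holds 2-(benzyl(methyl)amino)ethyl in place of that pyrrolidin-1-yl, and in this assay compound 3 gives 180 nM. Going by the values given here, the step of a 25-fold lower number from compound 1 to compound 3 (1.40 log units; beyond the scatter) is large, and compound 3 therefore stands lowest of the two numbers known, the stronger inhibitor of the pair.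

Compound 4 `COc1ccc(Br)cc1CCc1c(F)cccc1C(=O)/N=C(\N)NCC(C)C` differs from compound 3 by isopropyl in place of 3-(benzyl(methyl)amino)propyl on a saturated chain carbon bound to an amine nitrogen. Among the compounds with values here, the single measured step, from compound 1 to compound 3, swapped one amine-bearing group for another; here the whole amine-bearing part leaves and only a short branch remains, a change no measured step covers directly. Because a 25-fold lower number from compound 1 to compound 3 (1.40 log units; beyond the scatter) was large, a large move back toward higher numbers is expected for compound 4. The expected step is a 28-fold higher number from compound 3 to compound 4 (1.44 log units; beyond the scatter) for compound 4. The estimate for compound 4 in this assay is 5000 nM, with a range from 1000 nM to 30000 nM.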

Compound 4, half-maximal inhibitory concentration: 8500 nM
Compound 4: middle estimate off by 1.7-fold (0.23 log units), on the low side; the range from low to high includes it.
By their numbers in this assay, from the lowest: compound 3; then compounds 1 and 4 (each within the scatter of the next).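

In this assay, the step of a 47-fold higher number from compound 3 to compound 4 (1.67 log units; beyond the scatter) is large: with isopropyl in this place, the low number of compound 3 is gone, so that number depends on the 3-(benzyl(methyl)amino)propyl group or some part of it. The step of a 1.9-fold higher number from compound 1 to compound 4 (0.28 log units; within the scatter) lies within the scatter, so compound 1 and compound 4 cannot be told apart here. An amine at the end of the chain is therefore not enough on its own, since compound 1 has one and still does not reach the low number of compound 3. Nothing given here explains these steps.

Going by these compounds, it stays open whether the aromatic ring or the nitrogen of that group matters more. A 4-phenylbutyl chain, with the ring but no nitrogen, and a 4-(dimethylamino)butyl chain, with the nitrogen but no ring, would separate the two.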